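The source may report more compounds than this note shows. Statements on the series, on what has been measured and on what is new or still open speak of the compounds shown alone.

Compound 1, with the structure `O=[N+]([O-])c1ccc(S(=O)(=O)Nc2cccc3cc[nH]c23)cc1`, serves as the starting point. In a functional assay on KB cells (Homo sapiens) for antiproliferative activity, read by colorimetric assay and MTT assay (on this read-out higher numbers stand for weaker inhibition and lower numbers for stronger inhibition), compound 1 gives 15 ug/mL. Compound 2, with the structure `O=[N+]([O-])c1ccc(S(=O)(=O)Nc2ccc(Cl)c3cc[nH]c23)cc1`, carries one change against compound 1, namely (chloro in place of hydrogen on an aromatic carbon). In this assay compound 2 gives 9.1 ug/mL, which is a 1.6-fold lower number from compound 1 to compound 2 (0.22 log units; within the scatter), so the change left the result essentially where it was.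

Compound 3, with the structure `Nc1ccc(S(=O)(=O)Nc2cccc3c(Cl)c[nH]c23)cc1`, is built on a different core, and the difference between the two cores is not broken down here. In this assay compound 3 gives 10 ug/mL; compared with compound 2 and compound 1 the three numbers all lie within the usual scatter of one another, so no ordering among them can be read from the data.

Compound 4, with the structure `Nc1ccc(S(=O)(=O)Nc2ccc(Cl)c3c(Cl)c[nH]c23)cc1`, has not yet been measured. It differs from compound 3 by chloro in place of hydrogen on an aromatic carbon, the same change that separates compound 1 from compound 2, made on the same kind of position. Within the data shown here, with only one earlier example of this change, the expectation for compound 4 rests on that single step: because a 1.6-fold lower number from compound 1 to compound 2 (0.22 log units; within the scatter) stayed within the scatter, the step from compound 3 to compound 4 is estimated at a 1.4-fold lower number from compound 3 to compound 4 (0.15 log units; within the scatter). On that basis compound 4 is expected to give 7 ug/mL, most likely between 3.5 ug/mL and 14 ug/mL.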

Compound 4, half-maximal inhibitory concentration: 14 ug/mL
Beside the measured number, compound 4's estimate is 2.0-fold (0.30 log units) below it; the range from low to high includes it.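

In this assay, placing chloro in place of hydrogen on an aromatic carbon gives a 1.4-fold higher number from compound 3 to compound 4 (0.15 log units; within the scatter), so on this core too the change leaves the result essentially where it was. Set beside the earlier example, the two steps cannot be told apart, and the change looks no different on the two cores as far as these numbers can say: the same change on two cores in this assay, a 1.6-fold lower number (0.22 log units; within the scatter) from compound 1 to compound 2 and a 1.4-fold higher number (0.15 log units; within the scatter) from compound 3 to compound 4, 2.3-fold (0.36 log units) apart, within the scatter of two such steps. This supports only a modest statement, that neither core shows a clear response to chloro at this kind of position and that the two cores show no measurable difference in that response; with just two small steps, it does not prove that the change acts identically on both, and a modest real difference could stay hidden in the scatter.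

The compounds shown leave open whether a different group at this place, such as bromo, methyl or methoxy, would move the number beyond the scatter on either core. They also leave open how the nitro group and the amine compare when everything else in the structure stays the same.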